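Amide aryl variation at the carbonyl of the shared core

The source may report more compounds than this note shows. Statements on the series, on what has been measured and on what is new or still open speak of the compounds shown alone.

Three amides on a shared core have been measured in a functional assay on HepG2 cells (Homo sapiens) for antiproliferative activity, read by CCK-8 assay, with a stated time of 72 h; a higher number here means a weaker inhibitor, a lower number a stronger inhibitor. Compound 1 `COc1ccc(C(=O)Nc2cccc(-c3oc4cc(-c5ccc(F)cc5)ccc4c(=O)c3O)c2)cc1` gives 8420 nM. Compound 2 `Cc1ccc(C(=O)Nc2cccc(-c3oc4cc(-c5ccc(F)cc5)ccc4c(=O)c3O)c2)cc1` gives 2320 nM. Compound 3 `O=C(Nc1cccc(-c2oc3cc(-c4ccc(F)cc4)ccc3c(=O)c2O)c1)c1ccc(Cl)nc1` gives 4610 nM. The step of a 3.6-fold lower number from compound 1 to compound 2 (0.56 log units; beyond the scatter) is the only one beyond the scatter. Compound 3 stands second highest of the three numbers; the step of a 1.8-fold lower number from compound 1 to compound 3 (0.26 log units; within the scatter) and the step of a 2.0-fold higher number from compound 2 to compound 3 (0.30 log units; within the scatter) both fall within the scatter, so compound 3 cannot be ordered against compound 1 or compound 2 on these numbers.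

Compound 4 `O=C(Nc1cccc(-c2oc3cc(-c4ccc(F)cc4)ccc3c(=O)c2O)c1)c1ccc(-c2ccccc2)cc1` has not been measured. It differs from compound 3 in one place: 4-phenylphenyl in place of 6-chloropyridin-3-yl on a carbonyl carbon. For the measured compounds named here, the two measured steps that exchange the aryl group on the carbonyl carbon, a 1.8-fold lower number from compound 1 to compound 3 (0.26 log units; within the scatter) and a 2.0-fold higher number from compound 2 to compound 3 (0.30 log units; within the scatter), bear on this change, and both lie within the scatter; the one step beyond the scatter, a 3.6-fold lower number from compound 1 to compound 2 (0.56 log units; beyond the scatter), exchanges a substituent on that aryl group rather than the aryl group itself. Nothing measured here shows how a two-ring group at this place behaves. The expected step of a 1.3-fold lower number from compound 3 to compound 4 (0.12 log units; within the scatter) is therefore small, with no direction beyond the scatter. For compound 4 the estimate in this assay is 3500 nM, with a range from 1000 nM to 12000 nM.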

Compound 4, half-maximal inhibitory concentration: 88500 nM
Estimate against measurement, compound 4: 25-fold (1.40 log units) below, outside the stated range (above it).
By their numbers in this assay, from the lowest: compounds 2, 3 and 1 (each within the scatter of the next, the first and the last beyond it); then compound 4.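

For the compounds shown here, at the carbonyl carbon, a two-ring aryl group separates from the single-ring groups for the first time in this assay, with a 19-fold higher number from compound 3 to compound 4 (1.28 log units; beyond the scatter). Read as a substituent on the aromatic carbon, phenyl behaves unlike both smaller groups at that place, giving a 38-fold higher number from compound 2 to compound 4 (1.58 log units; beyond the scatter) and an 11-fold higher number from compound 1 to compound 4 (1.02 log units; beyond the scatter); each of these steps exceeds a 3.6-fold lower number from compound 1 to compound 2 (0.56 log units; beyond the scatter), the only step beyond the scatter among the three earlier amides, and compound 4 is the weakest of the four. Nothing available accounts for this sharp rise in the number, so it stands as an observation without an explanation.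

The compounds shown do not tell whether the rise follows from an aromatic second ring as such or would also appear with another group on that aromatic carbon, such as cyclohexyl, tert-butyl or a morpholine ring. A carboxylic acid or a dimethylamino group at the same place, or a phenyl group attached elsewhere on the amide aryl ring, would also test how narrow the tolerated range of groups is here.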